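Adding a second chloro to the purine-like core of compound 1

This account rests on a few compounds, and the source may have more. Where it says the series, first, only, none or still open, it means among the compounds named here.

Measured compounds:
compound 1, `ClCc1ccc(Cn2cnc3c(Cl)ncnc32)cc1`: 12900 nM
compound 2, `ClCc1ccccc1Cn1cnc2c(Cl)nc(Cl)nc21`: 2400 nM
compound 3, `ClCc1cccc(Cn2cnc3c(Cl)nc(Cl)nc32)c1`: 2390 nM

These three compounds were tested in a functional assay on A498 cells (Homo sapiens) for cytotoxicity, read by sulforhodamine B assay, with a stated time of 48 h; on this read-out lower numbers stand for stronger inhibition of growth and higher numbers for weaker inhibition of growth. Compound 1 gives 12900 nM, the highest number of the three and therefore the weakest growth inhibition seen here. Compound 2 gives 2400 nM and compound 3 gives 2390 nM; both lie well beyond the usual scatter away from compound 1, while the two of them sit within scatter of each other. Compound 2 and compound 3 share a fused core carrying two chloro groups, whereas compound 1 carries one, and the three differ as well in where the chloromethyl arm sits on the benzyl ring.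

Compound 4, `ClCc1ccc(Cn2cnc3c(Cl)nc(Cl)nc32)cc1`, has not yet been measured. It differs from compound 1 by chloro in place of hydrogen on an aromatic carbon. Within the data shown here, no measured pair shows this change on its own, so the expectation for compound 4 can only rest on compound 2 with 2400 nM and compound 3 with 2390 nM, which both carry the second chloro. On that basis compound 4 is expected to show a drop of about a 5.0-fold lower number from compound 1 to compound 4 (0.70 log units; beyond the scatter) toward stronger growth inhibition. The estimate for compound 4 in this assay is 2600 nM, with a likely range from 1000 nM to 7000 nM.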

Compound 4, concentration for 50% growth inhibition: 12000 nM
The estimate for compound 4 lay 4.6-fold (0.66 log units) below the measured number; measured number outside the range, above it.
By their numbers in this assay, from the lowest: compounds 3 and 2 (each within the scatter of the next); then compounds 4 and 1 (each within the scatter of the next).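

Placing a chloro on the aromatic carbon between two ring nitrogen atoms changes little on its own in this assay: the step is a 1.1-fold lower number from compound 1 to compound 4 (0.03 log units; within the scatter). Compound 2 at 2400 nM and compound 3 at 2390 nM carry the same second chloro as compound 4 and differ from it only in where the chloromethyl arm sits on the benzyl ring, so the second chloro alone does not bring the lower numbers seen with those two compounds. Nothing shown here gives a reason for this result.

Going by these compounds, what an amine or a methoxy group would do on this same carbon remains open. So does whether moving the chloromethyl arm would shift the number on the core of compound 1, which has only one chloro.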